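This account rests on a few compounds, and the source may have more. Where it says the series, first, only, none or still open, it means among the compounds named here.

Measured in a functional assay on DU-145 cells (Homo sapiens) for inhibition, read by trypan blue exclusion, with a stated time of 96 h; a higher number here means a weaker inhibitor of growth, a lower number a stronger inhibitor of growth:
- Compound 1 `Cc1ccc(S(=O)(=O)/C(=C/c2ccc(C)s2)C(=O)c2ccc(Cl)cc2)cc1`: 50000 nM
- Compound 2 `Cc1ccc(/C=C(\C(=O)c2ccc(Cl)cc2)S(=O)(=O)Cc2ccc(F)cc2)s1`: 50000 nM

Among the compounds with values here, compound 2 stands level with compound 1 in this assay, and nothing measured so far separates the two. The next compound, compound 3 `Cc1ccc(/C=C(\C(=O)c2ccc(Cl)cc2)S(=O)(=O)Cc2ccc(Cl)cc2Cl)s1`, changes the same part of the structure: 2,4-dichlorophenyl in place of 4-fluorophenyl on a saturated chain carbon bound to a sulfonyl sulfur. In words, it carries 2,4-dichlorophenyl in place of 4-fluorophenyl on a saturated chain carbon bound to a sulfonyl sulfur. Within the data shown here, only one measured step bears on this change, and it is no change at the digits printed from compound 1 to compound 2 (within the scatter), with 4-fluorobenzyl in place of 4-methylphenyl on a sulfonyl sulfur. Among the measured compounds shown here, no measured compound carries 2,4-dichlorobenzyl, so the data offer no firm direction, and no shift beyond the scatter is expected. The expected step is a 1.3-fold lower number from compound 2 to compound 3 (0.10 log units; within the scatter). For compound 3 the estimated value is 40000 nM, with an expected range from 12000 nM to 80000 nM.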

Compound 3, concentration for 50% growth inhibition: 10000 nM
Beside the measured number, compound 3's estimate is 4.0-fold (0.60 log units) above it, and the stated range ends above it.
By their numbers in this assay, from the lowest: compound 3; then compounds 1 and 2 (each within the scatter of the next).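

In this assay the place on a saturated chain carbon bound to a sulfonyl sulfur proves responsive to its substituent: 2,4-dichlorophenyl in place of 4-fluorophenyl gives a 5.0-fold lower number from compound 2 to compound 3 (0.70 log units; beyond the scatter) and so separates two compounds where the earlier change gave no change at the digits printed from compound 1 to compound 2 (within the scatter) in the same assay. Set against the 4-methylphenyl group on the sulfonyl sulfur, 2,4-dichlorobenzyl gives a 5.0-fold lower number from compound 1 to compound 3 (0.70 log units; beyond the scatter) and compound 3 is thus the strongest inhibitor of growth of the three shown. Nothing measured here accounts for this gain.

On these data alone, whether one chlorine is enough stays open, since a single compound cannot say if a 4-chlorobenzyl or a 2-chlorobenzyl group would match 2,4-dichlorobenzyl. As far as these compounds go, it is equally open how a longer chain between the sulfonyl sulfur and the dichlorophenyl ring, or an amine on that ring, would fare.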